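Replacing the group on the carbonyl of compound 3

The source may report more compounds than this note shows. Statements on the series, on what has been measured and on what is new or still open speak of the compounds shown alone.

In a functional assay (strain AB) with Danio rerio as the target, read by microscopy, with a stated time of 1 h (a higher number here means that more compound is needed for the effect, a lower number that less compound is needed), compound 1 `CCN1CCc2c(sc(NC(=O)Nc3ccc(Cl)cc3)c2C(N)=O)C1` gives 3120 nM. Compound 2 `CCN1CCc2c(sc(NC(=O)Nc3ccc(Cl)cc3)c2C(=O)NC)C1` is recorded only as a limit, > 25000 nM. Compound 3 `CCN1CCc2c(sc(NC(=O)Nc3ccc(Cl)cc3)c2C(=O)c2nc(C)no2)C1` is also recorded only as a limit, > 25000 nM. Compound 3 thus sits at the limit of > 25000 nM in this assay, at which 2 of the 3 values shown sit.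

Compound 4 `CCN1CCc2c(sc(NC(=O)Nc3ccc(Cl)cc3)c2C(=O)NC2COC2)C1` differs from compound 3 by (oxetan-3-yl)amino in place of 3-methyl-1,2,4-oxadiazol-5-yl on a carbonyl carbon. In words, it has (oxetan-3-yl)amino in place of 3-methyl-1,2,4-oxadiazol-5-yl on a carbonyl carbon.

Within the data shown here, two measured steps bear on this change. Compound 4, like compound 2, carries a group on the amide-type nitrogen, so an at least 8.0-fold higher number from compound 1 to compound 2 (0.90 log units; beyond the scatter) is the closest guide. The other relevant change on this carbonyl carbon is an at least 8.0-fold higher number from compound 1 to compound 3 (0.90 log units; beyond the scatter). Neither step suggests a return towards the value of compound 1, so no step beyond the scatter is expected in this assay, and a report as a limit is likely. For compound 4, the estimated change is an at least 1.1-fold lower number from compound 3 to compound 4 (0.05 log units; that floor lies within the scatter). Compound 4 is estimated at 22000 nM, with an expected range of 8000 nM to 50000 nM.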

Compound 4, half-maximal effective concentration: > 25000 nM
Compound 4 was reported as a limit; the forecaster's own chance of this, stated with the estimate: 70%; at least 1.1-fold (0.05 log units) between middle value and limit.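

Putting oxetan-3-yl in place of hydrogen on the amide-type nitrogen gives an at least 8.0-fold higher number from compound 1 to compound 4 (0.90 log units; beyond the scatter) in this assay. Methyl in compound 2 is thus no longer the only group on that nitrogen to end in a limit, and the result for compound 4 is itself a limit. Across the three replacements of amino on the carbonyl carbon, only compound 1 retains a measured number: the limit of > 25000 nM in this assay, at which 3 of the 4 values shown sit.

The steps among compound 2, compound 3 and compound 4 cannot be read, so methylamino, (oxetan-3-yl)amino and 3-methyl-1,2,4-oxadiazol-5-yl remain unranked against one another. As far as these compounds go, it also remains open whether amino alone gives a measured number on this carbonyl carbon, or whether a hydroxyl group or a carboxylic acid in its place would do so too.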